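This account rests on a few compounds, and the source may have more. Where it says the series, first, only, none or still open, it means among the compounds named here.

Measured compounds in a functional assay on PC-3 cells (Homo sapiens) for cytotoxicity, read by MTT assay, with a stated time of 48 h; a higher number here means a weaker inhibitor, a lower number a stronger inhibitor:
- compound 1, `COc1cc(-c2nnc3n2NC(c2ccco2)C(C(=O)c2ccco2)S3)cc(OC)c1OC`: compound 1 gives 58300 nM
- compound 2, `COc1cc(-c2nnc3n2NC(c2ccco2)C(C(=O)c2ccc(-c4ccccc4)cc2)S3)cc(OC)c1OC`: compound 2 gives 45900 nM
- compound 3, `COc1cccc(C(=O)C2Sc3nnc(-c4cc(OC)c(OC)c(OC)c4)n3NC2c2ccco2)c1`: compound 3 gives 84600 nM

All three share one core and differ only in the group on the carbonyl carbon. Compound 3 carries the highest of the three numbers, but the gaps are small: a 1.5-fold higher number from compound 1 to compound 3 (0.16 log units; within the scatter), a 1.8-fold higher number from compound 2 to compound 3 (0.27 log units; within the scatter), and also a 1.3-fold lower number from compound 1 to compound 2 (0.10 log units; within the scatter). None of these exceeds the scatter, so the three compounds cannot be ranked against each other.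

Compound 4, `COc1cc(-c2nnc3n2NC(c2ccco2)C(C(=O)c2ccc([N+](=O)[O-])cc2)S3)cc(OC)c1OC`, is the next step from compound 3. The change is 4-nitrophenyl in place of 3-methoxyphenyl on a carbonyl carbon. Among the compounds with values here, no measured pair shows a 4-nitrophenyl group, so nothing directly bears on this change. What the three measured steps do show is that swapping the group on the carbonyl carbon, among furan-2-yl, 4-phenylphenyl and 3-methoxyphenyl, moved the number only within the scatter each time. The expected step of a 1.2-fold lower number from compound 3 to compound 4 (0.08 log units; within the scatter) is therefore none beyond the scatter, in no particular direction. Compound 4 is estimated at 70000 nM, within a range from 25000 nM to 200000 nM.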

Compound 4, half-maximal inhibitory concentration: 27900 nM
Beside the measured number, compound 4's estimate is 2.5-fold (0.40 log units) above it; the measured number falls inside the stated range.
By their numbers in this assay, from the lowest: compounds 4, 2, 1 and 3 (each within the scatter of the next, the first and the last beyond it).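

In this assay the group on the carbonyl carbon can move the number beyond the scatter, which no earlier swap showed: 4-nitrophenyl in place of 3-methoxyphenyl gives a 3.0-fold lower number from compound 3 to compound 4 (0.48 log units; beyond the scatter) and 4-nitrophenyl in place of furan-2-yl gives a 2.1-fold lower number from compound 1 to compound 4 (0.32 log units; beyond the scatter) as two modest steps. Against the 4-phenylphenyl group there is no such separation, with a 1.6-fold lower number from compound 2 to compound 4 (0.22 log units; within the scatter) and so compound 4 and compound 2 cannot be told apart. Nothing measured on these compounds explains why this position responds as it does.

It remains open whether the nitro group itself matters, since the compounds shown include no 4-aminophenyl or 4-carboxyphenyl group at this position. As far as these compounds go, the rest of the core is also the same in all four compounds, so it is unknown whether these steps would hold on a different core.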